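Aromatic Replacement of a Hexylsulfanyl Chain in Compound 4

A few compounds are considered here, and "the series" means these few. Any claim that something is new, unique, unknown or untested is made for them only; others in the source may bear on it.

Three compounds have been measured in an assay on cells for antagonist activity at transient receptor potential cation channel subfamily V member 1 (Homo sapiens), read by FLIPR and calcium flux, with a stated time of 6 min; on this read-out higher numbers stand for weaker inhibition and lower numbers for stronger inhibition:

compound 1, `CC(C(=O)NCc1ccc(C(C)(C)C)nc1OC1CCCCC1)c1ccc(NS(C)(=O)=O)c(F)c1`, gives 2.5 nM
compound 2, `CCCCCSc1nc(C(C)(C)C)ccc1CNC(=O)C(C)c1ccc(NS(C)(=O)=O)c(F)c1`, gives 3.1 nM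
compound 3, `CCCCCCSc1nc(C(C)(C)C)ccc1CNC(=O)C(C)c1ccc(NS(C)(=O)=O)c(F)c1`, gives 1.5 nM

Compound 3 holds the lowest number of the three. Its separation from compound 1 is within the scatter, a 1.7-fold lower number from compound 1 to compound 3 (0.22 log units; within the scatter), while the step of a 2.1-fold lower number from compound 2 to compound 3 (0.32 log units; beyond the scatter) is beyond the scatter, though modest. The unmeasured compound 4, `COc1ccc(CSc2nc(C(C)(C)C)ccc2CNC(=O)C(C)c2ccc(NS(C)(=O)=O)c(F)c2)cc1`, differs from compound 3 by 4-methoxyphenyl in place of pentyl on a saturated chain carbon bound to a sulfur.

Two measured steps exchange the cyclohexyloxy group for an alkylsulfanyl chain, a 1.2-fold higher number from compound 1 to compound 2 (0.09 log units; within the scatter) and a 1.7-fold lower number from compound 1 to compound 3 (0.22 log units; within the scatter), both within the scatter; the third step lengthens that chain by one carbon, a 2.1-fold lower number from compound 2 to compound 3 (0.32 log units; beyond the scatter). None of them replaces an alkyl chain with an aromatic ring, so the step to compound 4 is not directly covered. Given how little the substituent at this position has moved the numbers so far, compound 4 is expected to stay close to compound 3, with a step of about a 2.0-fold higher number from compound 3 to compound 4 (0.30 log units; within the scatter). Compound 4 is therefore estimated at 3 nM, within a range from 1 nM to 10 nM.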

Compound 4, inhibition constant: 3.5 nM
Estimate against measurement, compound 4: 1.2-fold (0.07 log units) below; the range from low to high includes it.
By their numbers in this assay, from the lowest: compounds 3, 1, 2 and 4 (each within the scatter of the next, the first and the last beyond it).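

In this assay the saturated chain carbon bound to a sulfur now carries an aromatic ring, the first among these compounds, and 4-methoxyphenyl in place of pentyl gives a 2.3-fold higher number from compound 3 to compound 4 (0.37 log units; beyond the scatter) as a modest step. The picture depends on the reference: 4-methoxyphenyl in place of butyl gives a 1.1-fold higher number from compound 2 to compound 4 (0.05 log units; within the scatter) and (4-methoxybenzyl)sulfanyl in place of cyclohexyloxy gives a 1.4-fold higher number from compound 1 to compound 4 (0.15 log units; within the scatter) and both of these lie within the scatter, so the ring is tolerated and only the hexylsulfanyl chain stands apart from it. Nothing available explains this difference.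

Open, from the compounds shown here alone, is how a plain benzyl group on the sulfur, without the methoxy, would read in this assay here. A heptyl chain would show whether lengthening the alkyl chain goes on lowering the number.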